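Amide with dimethoxybenzyl on a trimethoxyphenyl triazole core

The source may report more compounds than this note shows. Statements on the series, on what has been measured and on what is new or still open speak of the compounds shown alone.

Of the compounds shown here, three sharing a core have been tested in a functional assay on HepG2 cells (Homo sapiens) for antiproliferative activity, read by MTT assay, with a stated time of 48 h; a lower number here means a stronger inhibitor, a higher number a weaker inhibitor. Compound 1 `COc1cc(-c2nnc(SCC(=O)c3ccccc3)n2N)cc(OC)c1OC` carries a phenyl ketone, and in this assay compound 1 gives 7800 nM. Compound 2 `COc1ccc(C(=O)CSc2nnc(-c3cc(OC)c(OC)c(OC)c3)n2N)cc1` adds a methoxy to that phenyl. In this assay compound 2 reaches only a limit, > 100000 nM. Compound 3 `COc1cc(-c2nnc(SCC(=O)Nc3ccccc3C)n2N)cc(OC)c1OC` replaces the ketone by an amide bearing a 2-methylphenyl group. In this assay compound 3 also reaches only a limit, > 100000 nM. Among the compounds with values here, compound 3 thus stands with compound 2 at the limit (the limit of > 100000 nM in this assay, at which 2 of the 3 values shown sit), while compound 1 is the only one with a real number.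

Compound 4 `COc1ccc(CNC(=O)CSc2nnc(-c3cc(OC)c(OC)c(OC)c3)n2N)cc1OC` is the next step: 3,4-dimethoxybenzyl in place of 2-methylphenyl on an amide-type nitrogen. Within the data shown here, two measured steps bear on it. The step of an at least 12-fold higher number from compound 1 to compound 3 (1.10 log units; beyond the scatter) shows that turning the ketone into the amide cost much activity, and the step of an at least 12-fold higher number from compound 1 to compound 2 (1.10 log units; beyond the scatter) shows that adding a methoxy on an aromatic carbon also did. The step that the two limits leave unreadable from compound 2 to compound 3 cannot be read, as both ends are limits. Compound 4 keeps the amide and adds two methoxy groups with a benzyl, so no gain is expected. The most likely outcome for compound 4 is again a limit, estimated around 100000 nM with a range from 20000 nM to 300000 nM. For compound 4 this means an expected step of a number no higher from compound 3 to compound 4 (the limit leaves the size open).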

Compound 4, half-maximal inhibitory concentration: > 100000 nM
Compound 4: only a limit was reported; the forecaster's own chance of this, stated with the estimate: 70%; the middle value sits exactly at the limit.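

Compound 3 and compound 4 both end at a limit rather than a real number, so the step between them cannot be read: the limit of > 100000 nM in this assay, at which 3 of the 4 values shown sit.

The compounds shown leave open how large the real numbers behind these limits are, and whether 3,4-dimethoxybenzyl and 2-methylphenyl on the amide-type nitrogen differ at all.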